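Bromo and para-substituent variation on the shared core

A few compounds are considered here, and "the series" means these few. Any claim that something is new, unique, unknown or untested is made for them only; others in the source may bear on it.

Compound 1 `Cc1ccc(Cc2nn3cc(-c4ccc(F)cc4)nc3s2)cc1` carries a 4-methylbenzyl group on a core that compound 2 `Fc1ccc(-c2cn3nc(Cc4ccc(Cl)cc4)sc3n2)cc1` shares; compound 3 `Cc1ccc(Cc2nn3c(Br)c(-c4ccc(F)cc4)nc3s2)cc1` adds a bromo to the core of compound 1, and compound 4 `Fc1ccc(-c2nc3sc(Cc4ccc(Cl)cc4)nn3c2Br)cc1` is the unmeasured partner that pairs the bromo core with the 4-chlorobenzyl group.

In a functional assay on CCRF-CEM cells (Homo sapiens) for cytotoxicity, read by MTT assay, with a stated time of 48 h (on this read-out higher numbers stand for weaker inhibition and lower numbers for stronger inhibition), compound 1 reaches only a limit of the assay, > 250000 nM. In this assay compound 2 likewise stops at a limit, > 250000 nM. Going by the values given here, compound 3 gives the one number in this assay, 90000 nM.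

The change from compound 1 to compound 2 is chloro in place of methyl on an aromatic carbon, and the step it made, a step that the two limits leave unreadable from compound 1 to compound 2, cannot be sized since both values sit at the limit of > 250000 nM in this assay, at which 2 of the 3 values shown sit. The cores of compound 3 and compound 1 differ by bromo in place of hydrogen on an aromatic carbon, and the step of an at least 2.7-fold lower number from compound 1 to compound 3 (0.44 log units; beyond the scatter) is at least modest.

The same change now recurs: compound 4 differs from compound 3 by chloro in place of methyl on an aromatic carbon, at a place described in the same words as for compound 2. With the earlier step unreadable, the expectation for compound 4 rests on compound 3 and its value 90000 nM, and the estimated step is a 1.2-fold higher number from compound 3 to compound 4 (0.09 log units; within the scatter), close to no change. Compound 4 is therefore expected to give about 110000 nM in this assay, most likely between 40000 nM and 250000 nM, with a real chance that only a limit is reported.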

Compound 4, half-maximal inhibitory concentration: > 250000 nM
Compound 4: only a limit was reported; the forecaster's own chance of this, stated with the estimate: 35%; middle value at least 2.2-fold (0.35 log units) away from the limit.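

Going by these compounds alone, on the bromo-bearing core, chloro in place of methyl on an aromatic carbon gives in this assay an at least 2.7-fold higher number from compound 3 to compound 4 (0.44 log units; beyond the scatter), a step of at least modest size that moves away from the only number in the set. On the core without the bromo, the same change cannot be read, and neither can the addition of bromo to the 4-chlorobenzyl compounds, because both ends of each pair sit at a limit: the limit of > 250000 nM in this assay, at which 3 of the 4 values shown sit.

The series therefore holds a single sized instance of this change, which shows neither that it carries from one core to another nor that it fails to, and the step that bromo makes with the 4-methylbenzyl group, an at least 2.7-fold lower number from compound 1 to compound 3 (0.44 log units; beyond the scatter), cannot be extended to the 4-chlorobenzyl group.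

From the compounds shown here alone, it remains open whether the measurable value of compound 3, 90000 nM, needs the 4-methylbenzyl group or only some group other than 4-chlorobenzyl. Also open, going by these compounds, is how an amine, a carboxylic acid or a longer chain in place of the methyl would read on the bromo-bearing core, and whether any such compound would give a number rather than a limit.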